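Acetyl to Nitro on Compounds Already Beyond Assay Reach

This account rests on a few compounds, and the source may have more. Where it says the series, first, only, none or still open, it means among the compounds named here.

Compound 1 `COc1ccc2c(c1)c(C=O)cn2Cc1cn([C@@H]2O[C@H](COC(C)=O)[C@@H](OC(C)=O)[C@H](OC(C)=O)[C@H]2OC(C)=O)nn1` gives > 200000 nM in a functional assay on HeLa cells (Homo sapiens) for cytotoxicity, read by sulforhodamine B assay, with a stated time of 48 h; on this read-out higher numbers stand for weaker inhibition and lower numbers for stronger inhibition.
Compound 2 `CC(=O)OC[C@H]1O[C@@H](n2cc(Cn3cc(C(C)=O)c4ccccc43)nn2)[C@H](OC(C)=O)[C@@H](OC(C)=O)[C@@H]1OC(C)=O` gives > 200000 nM in this assay.

Both of these readings are limits of the assay rather than numbers. For compound 1 the reading means only that no half-maximal inhibition was reached within the tested range. On these data alone, for compound 2 the reading is likewise a limit, so its true potency is unknown beyond that edge. Compound 2 therefore stands where every value shown sits, at the limit of > 200000 nM in this assay, at which 2 of the 2 values shown sit.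

The step to compound 3 `CC(=O)OC[C@H]1O[C@@H](n2cc(Cn3cc([N+](=O)[O-])c4ccccc43)nn2)[C@H](OC(C)=O)[C@@H](OC(C)=O)[C@@H]1OC(C)=O` is a single change: nitro in place of acetyl on an aromatic carbon, in words nitro in place of acetyl on an aromatic carbon. Among the measured compounds shown here, with no measured pair to compare, there is no basis for expecting a shift beyond the usual scatter in this assay, and the expected step is a step that the limit leaves unreadable from compound 2 to compound 3. Compound 3 is expected to give 300000 nM, with a likely range from 100000 nM to 1000000 nM, most probably again reported only as a limit.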

Compound 3, half-maximal inhibitory concentration: > 200000 nM
Compound 3 was reported as a limit; the forecaster's own chance of this, stated with the estimate: 85%; the middle value is on the limit's open side.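

Compound 2 and compound 3 are both reported only as limits in this assay, and no step can be read between them. The compounds shown leave open whether nitro in place of acetyl changes the read-out at all, and how potent any of these compounds really is.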